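A few compounds are considered here, and "the series" means these few. Any claim that something is new, unique, unknown or untested is made for them only; others in the source may bear on it.

Measured compounds, with their numbers in an assay on isolated protein for inhibition of alkaline phosphatase, tissue-nonspecific isozyme (Homo sapiens); a higher number here means a weaker inhibitor, a lower number a stronger inhibitor:
- compound 1 `COc1ccc(Cl)cc1S(=O)(=O)Nc1cncc(-c2cccnc2)c1`; compound 1 gives 73 nM
- compound 2 `CCNC(=O)c1cncc(NS(=O)(=O)c2cc(Cl)ccc2OC)c1`; compound 2 gives 193 nM
- compound 3 `COc1ccc(Cl)cc1S(=O)(=O)Nc1cncc(-c2cccc(C)c2)c1`; compound 3 gives 160 nM

Compound 3 stands second highest of the three numbers in this assay. Its nearest neighbour is compound 2, with a 1.2-fold lower number from compound 2 to compound 3 (0.08 log units; within the scatter), so these two cannot be told apart. Compound 1 gives the lowest number of the set, with a 2.2-fold higher number from compound 1 to compound 3 (0.34 log units; beyond the scatter) and a 2.6-fold higher number from compound 1 to compound 2 (0.42 log units; beyond the scatter), both beyond the scatter but still modest.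

Compound 4 `COc1ccc(Cl)cc1S(=O)(=O)Nc1cncc(-c2ccc(Cl)cc2)c1` is not yet measured. Its change from compound 3 is 4-chlorophenyl in place of 3-methylphenyl on an aromatic carbon. Among the measured compounds shown here, no measured step exchanges one carbon-only aromatic ring for another; the closest comparisons are the changes at this same aromatic carbon, a 2.2-fold higher number from compound 1 to compound 3 (0.34 log units; beyond the scatter) and a 1.2-fold lower number from compound 2 to compound 3 (0.08 log units; within the scatter), which stayed modest or within the scatter. The exchange of 3-methylphenyl for 4-chlorophenyl is therefore expected to give no step beyond the scatter in this assay, with compound 4 estimated at 150 nM, range 70 nM to 330 nM. The expected step is a 1.1-fold lower number from compound 3 to compound 4 (0.03 log units; within the scatter).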

Compound 4, half-maximal inhibitory concentration: 198 nM
Beside the measured number, compound 4's estimate is 1.3-fold (0.12 log units) below it, within the range that was stated.
By their numbers in this assay, from the lowest: compound 1; then compounds 3, 2 and 4 (each within the scatter of the next).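

In this assay, among the compounds shown here, the first exchange of one carbon-only aromatic ring for another at this aromatic carbon, 4-chlorophenyl in place of 3-methylphenyl, leaves the number unchanged within the scatter (a 1.2-fold higher number from compound 3 to compound 4 (0.09 log units; within the scatter)). The 4-chlorophenyl group also cannot be told apart from ethylcarbamoyl (a 1.0-fold higher number from compound 2 to compound 4 (0.01 log units; within the scatter)), so two different carbon-only aromatic rings and an amide all give similar numbers here. Only pyridin-3-yl stands apart, now also against 4-chlorophenyl (a 2.7-fold higher number from compound 1 to compound 4 (0.43 log units; beyond the scatter)), and nothing on hand accounts for this gap.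

From the compounds shown here alone, whether the substituent or its place on the phenyl ring counts remains open, as 3-chlorophenyl and 4-methylphenyl would separate the two. Also open, going by these compounds, are pyridin-4-yl, and an amine or carboxylic acid at this carbon.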